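A Pyridyl Swap at the Triple-Bonded Carbon

This account rests on a few compounds, and the source may have more. Where it says the series, first, only, none or still open, it means among the compounds named here.

Measured compounds:
Compound 1, `CONc1nc(C#CCC(C)O)nc2c1ncn2[C@@H]1O[C@H](CO)[C@@H](O)[C@H]1O`: 5.4 nM
Compound 2, `CONc1nc(C#Cc2ccccn2)nc2c1ncn2[C@@H]1O[C@H](CO)[C@@H](O)[C@H]1O`: 2.3 nM

Both compounds were tested in an assay on CHO cells for displacement of a labelled ligand from adenosine receptor A3 (Homo sapiens); on this read-out lower numbers stand for stronger inhibition and higher numbers for weaker inhibition. Compound 2 gives the lower of the two numbers; its nearest neighbour is compound 1, and the two are separated by the step of a 2.3-fold lower number from compound 1 to compound 2 (0.37 log units; beyond the scatter), a change of the whole group on the triple-bonded carbon.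

Compound 3, `CONc1nc(C#Cc2ccncc2)nc2c1ncn2[C@@H]1O[C@H](CO)[C@@H](O)[C@H]1O`, has not yet been measured. It differs from compound 2 by pyridin-4-yl in place of pyridin-2-yl on a triple-bonded carbon. Going by the values given here, no measured step bears directly on this change: the only step available, a 2.3-fold lower number from compound 1 to compound 2 (0.37 log units; beyond the scatter), exchanges a hydroxypropyl chain for a pyridyl ring rather than moving the nitrogen within a pyridyl ring, so it offers only a loose guide and shows that the pyridyl end point sits comfortably at the low end of the numbers seen. With the same atoms joined differently, the expected step of a 1.5-fold higher number from compound 2 to compound 3 (0.18 log units; within the scatter) is within the scatter, leaning if anything toward a slightly higher number. Compound 3 is therefore estimated at 3.5 nM, with a range from 1.2 nM to 12 nM.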

Compound 3, inhibition constant: 6 nM
Estimate against measurement, compound 3: 1.7-fold (0.23 log units) below; low and high end bracket the measured number.
By their numbers in this assay, from the lowest: compound 2; then compounds 1 and 3 (each within the scatter of the next).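

The exchange of pyridin-2-yl for pyridin-4-yl on a triple-bonded carbon, with the same atoms joined differently, gives the first view of how the joining of the pyridyl ring counts in this assay, and it amounts to a 2.6-fold higher number from compound 2 to compound 3 (0.42 log units; beyond the scatter). The read-out at this position therefore depends on more than the presence of a pyridyl ring: the gain seen with pyridin-2-yl over 2-hydroxypropyl does not carry over to pyridin-4-yl, which shows only a 1.1-fold higher number from compound 1 to compound 3 (0.05 log units; within the scatter). No measurement at hand accounts for the difference between the two pyridyl compounds.

From the compounds shown here alone, it remains open whether pyridin-3-yl on the same triple-bonded carbon would read closer to compound 2 or to compound 3, and whether a plain phenyl ring would match either of them. Also open, going by these compounds, is whether the exchange of pyridin-2-yl for pyridin-4-yl would read the same if the methoxyamino group on the shared core gave way to a plain amine.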